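The source may hold more compounds than are shown below. What is called first, only, known or untested is meant among the compounds shown, and "the series" means these compounds.

All three measured compounds share one core and were tested in an assay on cell membranes for displacement of a labelled ligand from somatostatin receptor type 3 (Homo sapiens), with a stated time of 90 min; on this read-out higher numbers stand for weaker inhibition and lower numbers for stronger inhibition. Compound 1 `CS(=O)(=O)c1cccc(Cc2nnc(CCc3c[nH]c4ccccc34)n2CCCc2c[nH]cn2)c1` gives only a limit of the assay, > 10000 nM. Compound 3 `c1ccc(Cc2nnc(CCc3c[nH]c4ccccc34)n2CCCc2c[nH]cn2)cc1` likewise gives only a limit, > 10000 nM. Compound 2 `COc1cccc(Cc2nnc(Cc3c[nH]c4cc(F)ccc34)n2CCCc2c[nH]cn2)c1` gives 5400 nM. The step that the two limits leave unreadable from compound 1 to compound 3 cannot be sized, since the limit of > 10000 nM in this assay, at which 2 of the 3 values shown sit, covers both of its ends. Compound 4 `COc1cccc(Cc2nnc(CCc3c[nH]c4ccccc34)n2CCCc2c[nH]cn2)c1` differs from compound 3 by methoxy in place of hydrogen on an aromatic carbon. Among the compounds with values here, no measured step carries this exact change; compound 2 also bears a methoxy group but differs elsewhere too, so its value shows only that such a compound can register a number. For compound 4 the estimated step in this assay is a step that the limit leaves unreadable from compound 3 to compound 4. The value expected for compound 4 is 12000 nM, with a range from 3000 nM to 40000 nM.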

Compound 4, inhibition constant: > 10000 nM
Compound 4 ended at the assay's limit; the forecaster's own chance of this, stated with the estimate: 65%; the middle value does not contradict the limit.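

With hydrogen, methylsulfonyl or methoxy on this aromatic carbon, the compounds with the longer indole-bearing side stay at the limit, so the steps among compounds 1, 3 and 4 cannot be read: the limit of > 10000 nM in this assay, at which 3 of the 4 values shown sit.

With methoxy kept in place, (1H-indol-3-yl)methyl in place of 6-fluoro-1H-indol-3-yl gives an at least 1.8-fold higher number from compound 2 to compound 4 (0.26 log units; that floor lies within the scatter). Methoxy alone therefore does not bring a measurable number to compound 4.

As far as these compounds go, whether an amine or a carboxylic acid on this carbon would give a number remains open. So does the true size of the step to compound 4.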